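Naphthalen-1-yl on the sulfonamide nitrogen of compound 2

The source may hold more compounds than are shown below. What is called first, only, known or untested is meant among the compounds shown, and "the series" means these compounds.

In a functional assay on MCF7 cells (Homo sapiens) for antiproliferative activity, read by MTT assay, with a stated time of 72 h (a higher number here means a weaker inhibitor, a lower number a stronger inhibitor), compound 1 `COc1cccc(N(C)S(=O)(=O)C2CC3OC2C(c2ccc(NC(=O)CCCCCCC(=O)O)cc2)=C3c2ccc(O)cc2)c1` gives 39400 nM and compound 2 `CN(c1ccc(Cl)cc1)S(=O)(=O)C1CC2OC1C(c1ccc(NC(=O)CCCCCCC(=O)O)cc1)=C2c1ccc(O)cc1` gives 13700 nM, the lower of the two numbers. Compound 3 `CN(c1cccc2ccccc12)S(=O)(=O)C1CC2OC1C(c1ccc(NC(=O)CCCCCCC(=O)O)cc1)=C2c1ccc(O)cc1`, not yet measured, carries naphthalen-1-yl in place of 4-chlorophenyl on a sulfonamide nitrogen. Among the measured compounds shown here, one measured step bears on this place: a 2.9-fold lower number from compound 1 to compound 2 (0.46 log units; beyond the scatter), a modest change that brought in the 4-chlorophenyl now leaving. A single step sets no trend, and the data show nothing yet on naphthalen-1-yl, so no direction can be argued with confidence. The expected step in this assay is no larger than that modest one. The estimated step, a 1.1-fold higher number from compound 2 to compound 3 (0.04 log units; within the scatter), is expected to stay within the scatter. For compound 3 the estimate is 15000 nM, with an expected range of 6000 nM to 38000 nM.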

Compound 3, half-maximal inhibitory concentration: 14000 nM
For compound 3 the middle estimate is 1.1-fold (0.03 log units) above the measured one; low and high end bracket the measured number.
By their numbers in this assay, from the lowest: compounds 2 and 3 (each within the scatter of the next); then compound 1.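

In this assay, naphthalen-1-yl on the sulfonamide nitrogen reads the same as 4-chlorophenyl, with a 1.0-fold higher number from compound 2 to compound 3 (0.01 log units; within the scatter), so going from one six-membered aromatic ring to two leaves the number unchanged at this place. Against 3-methoxyphenyl, naphthalen-1-yl gives a 2.8-fold lower number from compound 1 to compound 3 (0.45 log units; beyond the scatter), which leaves compound 1 as the only one of the three set apart, while compound 2 and compound 3 stand level. No measured data explain why these two groups match or why 3-methoxyphenyl differs.

Going by these compounds, a pyridin-3-yl ring, a benzyl group or a cyclohexyl ring at this place remains open, as does whether a non-aromatic group would hold the level of compound 2 and compound 3. Replacing the methyl on the same nitrogen with hydrogen or ethyl also remains untested in the compounds shown.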